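The compounds below may be only part of what the source reports. "The series", "measured", "known", "first", "only" and "open" are said of these compounds alone.

In a functional assay on KB cells (Homo sapiens) for cytotoxicity (on this read-out lower numbers stand for stronger inhibition and higher numbers for weaker inhibition), three compounds sharing one core have been measured. Compound 1 `CCCOC1=CC(=O)c2ccccc2C1=O`, with propyl on the oxygen, gives 49400 nM. Compound 2 `C/C=C/C(=O)OC1=CC(=O)c2ccccc2C1=O`, with (prop-1-en-1-yl)carbonyl there, gives 64200 nM. Compound 3 `CCCCOC1=CC(=O)c2ccccc2C1=O`, with butyl, gives 27000 nM. Compound 3 therefore cannot be told apart from compound 1, while it does separate from compound 2, with a 2.4-fold lower number from compound 2 to compound 3 (0.38 log units; beyond the scatter).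

Compound 4 `CCOC1=CC(=O)c2ccccc2C1=O` shortens the chain of compound 3: hydrogen in place of ethyl on a saturated chain carbon, two bonds along the chain from an oxygen on an unsaturated carbon, so butoxy becomes ethoxy. The closest guide is the change from propyl to butyl, a 1.8-fold lower number from compound 1 to compound 3 (0.26 log units; within the scatter). The other step, a 1.3-fold higher number from compound 1 to compound 2 (0.11 log units; within the scatter), swaps in a different kind of group and offers little here. Read in reverse, the propyl to butyl step points to a higher number for a shorter chain, though it is only one step. The expected change is a 2.6-fold higher number from compound 3 to compound 4 (0.41 log units; beyond the scatter). For compound 4 the estimate is 70000 nM, with an expected range from 35000 nM to 130000 nM.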

Compound 4, half-maximal inhibitory concentration: 16900 nM
The estimate for compound 4 lay 4.1-fold (0.62 log units) above the measured number; measured number below the stated range.
By their numbers in this assay, from the lowest: compounds 4, 3, 1 and 2 (each within the scatter of the next, the first and the last beyond it).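

In this assay, cutting butyl down to ethyl on the oxygen brings no rise in the number, as the propyl to butyl step had suggested it might: the change gives a 1.6-fold lower number from compound 3 to compound 4 (0.20 log units; within the scatter), so the two chains cannot be told apart. Ethyl does separate from the other two groups, with a 2.9-fold lower number from compound 1 to compound 4 (0.47 log units; beyond the scatter) and a 3.8-fold lower number from compound 2 to compound 4 (0.58 log units; beyond the scatter), so among compounds 4, 1 and 3 the number does not simply fall as the chain grows, and compound 1, with its propyl, goes against such a trend. No measurement at hand explains why these chains behave this way.

The compounds shown leave open what a methyl on the oxygen, or a longer chain such as hexyl, would give. They also leave open whether a chain ending in an amine or a carboxylic acid would fit at this position.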